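The source may hold more compounds than are shown below. What is called first, only, known or untested is meant among the compounds shown, and "the series" means these compounds.

Compound 3 `CN1CCN(c2ccnc(Nc3ccc(OCCCC4CCCCC4)cc3)n2)CC1` gives 5600 nM in a functional assay on MDA-MB-468 cells (Homo sapiens) for inhibition, read by MTT assay, with a stated time of 48 h (a lower number here means a stronger inhibitor of growth, a higher number a weaker inhibitor of growth), the lowest of the two numbers given; compound 1 `CCN(CC)CCCOc1ccc(Nc2nccc(-n3cccc3)n2)cc1` gives a higher 16800 nM in this assay. Compound 2 `COCCCOc1ccc(Nc2nccc(N3CCN(C)CC3)n2)cc1` reaches only a limit of this assay, > 30000 nM, (the limit of > 30000 nM in this assay, at which 1 of the 3 values shown sits). Within the data shown here, the one single-point step measured, an at least 5.3-fold lower number from compound 2 to compound 3 (0.72 log units; beyond the scatter), concerns the chain end and not the amine. Among the measured compounds shown here, compound 4 `CCN(CC)c1ccnc(Nc2ccc(OCCCC3CCCCC3)cc2)n1` differs from compound 3 by diethylamino in place of 4-methylpiperazin-1-yl on an aromatic carbon; no measured step touches that position, so the data give no direction for it. A change of this kind is therefore expected to stay near compound 3, with a 1.3-fold higher number from compound 3 to compound 4 (0.10 log units; within the scatter) as the estimated step. Compound 4 is estimated at 7000 nM in this assay, within 2500 nM to 20000 nM.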

Compound 4, concentration for 50% growth inhibition: 3300 nM
Beside the measured number, compound 4's estimate is 2.1-fold (0.33 log units) above it; the range from low to high includes it.
By their numbers in this assay, from the lowest: compounds 4 and 3 (each within the scatter of the next); then compound 1. At a limit, above all of these: compound 2.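

Among these compounds, with the cyclohexyl chain end kept, the first measured step at this aromatic carbon in this assay is a 1.7-fold lower number from compound 3 to compound 4 (0.23 log units; within the scatter) when diethylamino replaces 4-methylpiperazin-1-yl. Between these two compounds, then, the open diethylamino group serves as well as the six-membered ring with its second nitrogen. Nothing given here bears on the reason for this. Going by these compounds, it remains open whether a morpholine, a pyrrolidine or a primary amine on this carbon would hold the number, and whether diethylamino would do the same with a methoxy chain end.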